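From Phenyl to 5-Chloropyridin-2-yl on an Amine Nitrogen

The compounds below may be only part of what the source reports. "The series", "measured", "known", "first", "only" and "open" are said of these compounds alone.

Measured so far:
Compound 1, `Fc1ccccc1NCc1ccc(CNc2ccccc2F)cc1`: 58%
Compound 2, `c1ccc(NCc2ccc(CNc3ncccn3)cc2)cc1`: 100%

In a functional assay on MDA-MB-231 cells for antagonist activity at C-X-C chemokine receptor type 4 (Homo sapiens), tested at 100 nM (a higher number here means a stronger effect of the compound at the concentration tested, a lower number a weaker effect), compound 2 gives 100%, the higher of the two numbers, and compound 1 lies well beyond the usual scatter beneath it. Compound 3, `Clc1ccc(NCc2ccc(CNc3ncccn3)cc2)nc1`, differs from compound 2 in a single place: 5-chloropyridin-2-yl in place of phenyl on an amine nitrogen. Going by the values given here, no step between measured compounds covers this change, so its effect must be guessed from the numbers at hand. Because compound 2 already gives 100% in this assay, there is no room upward, and the step of a number 10 percentage points lower from compound 2 to compound 3 (within the scatter) is expected to be none beyond the scatter, with some chance of a modest fall. Compound 3 is therefore estimated at 90%, most likely between 65% and 100%.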

Compound 3, a percentage reported as inhibition, at one concentration (the size of the read-out at that concentration, not a potency): 100%
For compound 3 the middle estimate is 10 percentage points below the measured one, and the stated range covers the measured number.
By their numbers in this assay, from the lowest: compound 1; then compounds 2 and 3 (each within the scatter of the next).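

In this assay the exchange of phenyl for 5-chloropyridin-2-yl on an amine nitrogen gives no change at the digits printed from compound 2 to compound 3 (within the scatter), which shows that this position accepts a ring with a hetero atom and a chlorine in place of a ring of carbon only. With compound 3 at 100%, the read-out at this one concentration cannot separate compound 3 from compound 2, and any stronger effect at this concentration would stay hidden. No measurement shown here explains this result.

The compounds shown leave open what the ring nitrogen and the chlorine each contribute, which pyridin-2-yl without the chlorine would begin to separate, and whether a saturated ring such as cyclohexyl would serve on the same amine nitrogen. They also leave open how compound 2 and compound 3 compare at concentrations other than the one tested.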